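Swapping Phenyl for an Ester on the Five-Membered Ring

The source may report more compounds than this note shows. Statements on the series, on what has been measured and on what is new or still open speak of the compounds shown alone.

Compound 1 `Cc1c(-c2csc(NC(=S)Nc3ccccc3)n2)c(=O)n(-c2ccccc2)n1C`: 8350 nM
Compound 2 `Cc1c(-c2csc(/N=c3\sc(-c4ccccc4)nn3-c3ccccc3)n2)c(=O)n(-c2ccccc2)n1C`: > 100000 nM
Compound 3 `CC(=O)c1nn(-c2ccc([N+](=O)[O-])cc2)/c(=N/c2nc(-c3c(C)n(C)n(-c4ccccc4)c3=O)cs2)s1`: > 100000 nM

All three measured compounds were tested in a functional assay on HepG2 cells (Homo sapiens) for cytotoxicity, read by sulforhodamine B assay, with a stated time of 72 h; on this read-out lower numbers stand for stronger inhibition and higher numbers for weaker inhibition. Compound 1 gives a real number there, 8350 nM. Compound 2, by contrast, reaches only a limit of the assay, > 100000 nM, so no exact number is known for it. Compound 3 likewise sits at a limit, > 100000 nM. No pair among these three differs in a single place, so no measured step can be drawn from them, and compound 2 stands simply among the two that lie at the limit.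

Compound 4 `CCOC(=O)c1nn(-c2ccccc2)/c(=N/c2nc(-c3c(C)n(C)n(-c4ccccc4)c3=O)cs2)s1` is the not yet measured partner of compound 2. The change is ethoxycarbonyl in place of phenyl on an aromatic carbon. Because (the limit of > 100000 nM in this assay, at which 2 of the 3 values shown sit), the starting point is already beyond what this assay can resolve, and the step from compound 2 to compound 4 is expected to be a number no higher from compound 2 to compound 4 (the limit leaves the size open), essentially none beyond the scatter. Compound 4 is therefore expected to give about 100000 nM, within 30000 nM to 300000 nM, most likely reported again only as a limit.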

Compound 4, half-maximal inhibitory concentration: > 100000 nM
Compound 4: a limit, no number (the forecaster's own chance of this, stated with the estimate: 70%); the middle value sits exactly at the limit.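

Compound 2 and compound 4 both reach only a limit in this assay, so no step can be read between them: the limit of > 100000 nM in this assay, at which 3 of the 4 values shown sit.

Whether ethoxycarbonyl in place of phenyl on an aromatic carbon changes cytotoxicity at all stays open, and the compounds shown give no real number for either group.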